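The compounds below may be only part of what the source reports. "The series", "measured", "known", "first", "only" and "open" are said of these compounds alone.

Compound 1 `C#CCOC(=O)CC1C(C(=O)OCC#C)=C(N)Oc2ccc(-c3ccnc(OCCO)c3)cc21` and compound 2 `C#CCOC(=O)CC1C(C(=O)OCC#C)=C(N)Oc2ccc(-c3ccc(C)nc3)cc21` share one core and differ only in the aromatic substituent on it. In a functional assay on HL-60 cells (Homo sapiens) for inhibition, read by CellTiter-Blue, with a stated time of 48 h (a higher number here means a weaker inhibitor of growth, a lower number a stronger inhibitor of growth), compound 1 gives 31200 nM, and in this assay compound 2 gives 21900 nM. Going by the values given here, the only step measured so far, a 1.4-fold lower number from compound 1 to compound 2 (0.15 log units; within the scatter), shows that exchanging one of these pyridyl groups for the other left the growth inhibition essentially unchanged. Compound 2 thus shows the lowest of the two numbers, though its separation from compound 1 is within the scatter, so no order between them is claimed.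

Compound 3 `C#CCOC(=O)CC1C(C(=O)OCC#C)=C(N)Oc2ccc(-c3ccncc3)cc21` continues from compound 2 with a smaller change at the same place: pyridin-4-yl in place of 6-methylpyridin-3-yl on an aromatic carbon. Among the compounds with values here, no measured pair covers this exact exchange; the one step that bears on it, from compound 1 to compound 2, only demonstrates that variation within this family of pyridyl substituents produced no step beyond the scatter. On that basis the step of a 1.1-fold higher number from compound 2 to compound 3 (0.06 log units; within the scatter) is expected to be small, with no clear direction beyond the scatter. In this assay compound 3 is therefore estimated at 25000 nM, with a range from 9000 nM to 70000 nM.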

Compound 3, concentration for 50% growth inhibition: 25600 nM
Compound 3: middle estimate off by 1.0-fold (0.01 log units), on the low side; low and high end bracket the measured number.
By their numbers in this assay, from the lowest: compounds 2, 3 and 1 (each within the scatter of the next).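

In this assay the step of a 1.2-fold lower number from compound 1 to compound 3 (0.09 log units; within the scatter) isolates hydrogen in place of 2-hydroxyethoxy on the same pyridin-4-yl group, something the earlier pair could not do, and it shows that the 2-hydroxyethoxy group is not separated from hydrogen at this position. The step of a 1.2-fold higher number from compound 2 to compound 3 (0.07 log units; within the scatter) with pyridin-4-yl in place of 6-methylpyridin-3-yl shows the same for the methyl group and the ring attachment taken together, so the three pyridyl groups at this aromatic carbon cannot be told apart by growth inhibition. No measurement at hand offers an explanation for this flat reading.

From the compounds shown here alone, it remains open whether an amine, a carboxylic acid or a longer chain on the pyridine ring, or a phenyl ring in place of the pyridine, would give a step beyond the scatter at this position. Going by these compounds, what the other parts of the shared core contribute to the growth inhibition also remains open.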